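Nitro biphenyls: ethoxy to dimethylamino swap

This account rests on a few compounds, and the source may have more. Where it says the series, first, only, none or still open, it means among the compounds named here.

In an assay on COS-7 cells for inhibition of patatin-like phospholipase domain-containing protein 2 (Mus musculus) (a lower number here means a stronger inhibitor, a higher number a weaker inhibitor), compound 1 `CCOC(=O)c1cccc(-c2ccc(N(C)C)cc2)c1` gives 40000 nM. Compound 2 `CCOc1ccc(-c2cccc([N+](=O)[O-])c2)cc1` reaches only a limit of the assay, > 200000 nM. Compound 2 thus stands at the limit of > 200000 nM in this assay, at which 1 of the 2 values shown sits, with no number of its own. Compound 3 `CN(C)c1ccc(-c2cccc([N+](=O)[O-])c2)cc1` differs from compound 2 by dimethylamino in place of ethoxy on an aromatic carbon. Going by the values given here, no measured pair shows this swap, and compound 1 carries its dimethylamino on a core bearing a different second group. The expected step of an at least 1.6-fold lower number from compound 2 to compound 3 (0.22 log units; that floor lies within the scatter) is modest and uncertain, leaning toward a gain. Compound 3 is estimated at 120000 nM, within 30000 nM to 400000 nM, with a fair chance of another limit.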

Compound 3, half-maximal inhibitory concentration: > 200000 nM
Compound 3: a limit, no number; the forecaster's own chance of this, stated with the estimate: 55%; middle value at least 1.6-fold (0.22 log units) away from the limit.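

Compound 3 gives > 200000 nM in this assay, a limit and not a number, so the step from compound 2 cannot be read and dimethylamino in place of ethoxy yields no measurable gain on this core. With dimethylamino held, nitro in place of ethoxycarbonyl on an aromatic carbon gives an at least 5.0-fold higher number from compound 1 to compound 3 (0.69 log units; beyond the scatter). Both nitro compounds now stand at the limit: the limit of > 200000 nM in this assay, at which 2 of the 3 values shown sit.

On these data alone, whether an ester other than ethoxycarbonyl, or a carboxylic acid, would keep a readable number remains open. So does the effect of a primary amine or a longer alkoxy chain in place of dimethylamino.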